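This account rests on a few compounds, and the source may have more. Where it says the series, first, only, none or still open, it means among the compounds named here.

Compound 1 `CCCCc1noc(-c2ccc(C(=O)NC[C@H]3CCCC3(C)C)cc2)n1` gives 2 nM in an assay for activation of potassium voltage-gated channel subfamily KQT member 1 (Cavia porcellus); on this read-out lower numbers stand for stronger inhibition and higher numbers for weaker inhibition. Compound 3 `Cc1noc(-c2ccc(C(=O)NCC3CCCC3(C)C)cc2)n1` gives 580 nM; 220 nM (2 entries) in this assay, and its repeated entries the several entries of compound 3 in this assay, 580 nM; 220 nM (2 entries) show how far single readings may wander. Compound 2 `CCCCCCOc1ccc(C(=O)NCC2CCCC(C)(C)C2)cc1` gives 370 nM in this assay, the higher of the two single numbers, with compound 1 the nearest neighbour on the scale. Compound 4 `CCCCCCOc1ccc(C(=O)NCCC(C)(C)C)cc1` has not yet been tested. It differs from compound 2 by neopentyl in place of 3,3-dimethylcyclohexyl on a saturated chain carbon bound to an amide-type nitrogen. Going by the values given here, no measured pair isolates this change, so the account expects a modest step in this assay toward a higher number, likely beyond the scatter. For compound 4 the expected value in this assay is 1100 nM, between 300 nM and 4500 nM. The expected step is a 3.0-fold higher number from compound 2 to compound 4 (0.47 log units; beyond the scatter).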

Compound 4, half-maximal inhibitory concentration: 250 nM
Estimate against measurement, compound 4: 4.4-fold (0.64 log units) above; measured number below the stated range.
By their numbers in this assay, from the lowest: compound 1; then compounds 4 and 2 (each within the scatter of the next).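

Setting neopentyl in place of 3,3-dimethylcyclohexyl on a saturated chain carbon bound to an amide-type nitrogen gives a 1.5-fold lower number from compound 2 to compound 4 (0.17 log units; within the scatter) in this assay. On this core, then, the six-membered non-aromatic ring is not needed to hold a number at this level. Repeated readings in this series also differ noticeably: the several entries of compound 3 in this assay, 580 nM; 220 nM (2 entries)

On these data alone, it remains open whether an amine or a carboxylic acid on this chain would keep the number. Also open, as far as these compounds go, is whether neopentyl would do as well on the core of compound 1, which gives 2 nM.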